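The compounds below may be only part of what the source reports. "The series", "measured", "known", "first", "only" and "open" are said of these compounds alone.

Compound 2 `O=C(Nc1cccc(-n2cc(-c3ccncc3)c(-c3cc(O)cc(Cl)c3)n2)c1)c1cc(C(F)(F)F)cc(C(F)(F)F)c1` has the lower of the two numbers in hand: in a functional assay on NCI-H23 cells (Homo sapiens) for inhibition, read by sulforhodamine B assay, with a stated time of 48 h, tested at 10 uM (on this read-out higher numbers stand for a weaker effect at the one concentration tested and lower numbers for a stronger effect), compound 2 gives 42.7%, whereas compound 1 `COc1cc(Cl)cc(-c2nn(-c3cccc(NC(=O)c4cccc(C(F)(F)F)c4)c3)cc2-c2ccncc2)c1` gives 55.7%, a number that lies above that of compound 2 beyond the scatter. Compound 3 `COc1cc(Cl)cc(-c2nn(-c3cccc(NC(=O)c4cc(C(F)(F)F)cc(C(F)(F)F)c4)c3)cc2-c2ccncc2)c1` is not yet measured; it differs from compound 2 in one place (methyl in place of hydrogen on an oxygen on an aromatic ring). Among the compounds with values here, no measured pair isolates this change, so the step is expected to be small, in either direction or none beyond the scatter: from compound 2 to compound 3 the change expected is a number 7.3 percentage points higher from compound 2 to compound 3 (within the scatter). For compound 3 the estimate in this assay is 50%, with a range from 35% to 65%.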

Compound 3, a percentage reported as activity, at one concentration (the size of the read-out at that concentration, not a potency): 72.1%
The estimate for compound 3 lay 22.1 percentage points below the measured number, outside the stated range (above it).
By their numbers in this assay, from the lowest: compound 2; then compound 1; then compound 3.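

In this assay the change from hydroxy to methoxy now has a clean pair: it gives a number 29.4 percentage points higher from compound 2 to compound 3 (beyond the scatter), a weaker effect at the one concentration tested. Within the data shown here, with the methoxy held, trifluoromethyl in place of hydrogen on an aromatic carbon also weakens the effect, with a number 16.4 percentage points higher from compound 1 to compound 3 (beyond the scatter), so a second trifluoromethyl brings no gain in this pair. Nothing measured on these compounds gives a reason for either step.

On these data alone, whether the second trifluoromethyl would also weaken the effect with the hydroxy in place remains open. So does the reading at this position with an ethyl on the oxygen, or with an amine in place of the hydroxy.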